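The source may report more compounds than this note shows. Statements on the series, on what has been measured and on what is new or still open speak of the compounds shown alone.

Working notes on the series. In a functional assay on LNCaP cells (Homo sapiens) for antiproliferative activity, read by propidium iodide staining, with a stated time of 96 h (on this read-out lower numbers stand for stronger inhibition and higher numbers for weaker inhibition), compound 1 (`CC(O)(CSc1ccc(S(F)(F)(F)(F)F)cc1)C(=O)Nc1ccc(C#N)c(C(F)(F)F)c1`) gives 16900 nM and compound 2 (`CC(O)(CSc1ccc(F)cc1)C(=O)Nc1ccc(S(F)(F)(F)(F)F)cc1`) gives 12500 nM as its value. Within the data shown here, these two values lie within the scatter of each other, so compound 2 cannot be ranked apart from compound 1 on the numbers so far. Among the measured compounds shown here, the two compounds differ in more than one place, and no single-change step between measured compounds is available.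

Compound 3 (`CC(O)(CSc1ccccc1C(F)(F)F)C(=O)Nc1ccc(S(F)(F)(F)(F)F)cc1`) is the next entry to be read in this assay and differs from compound 2 in one place. On a sulfur whose other neighbours are a saturated chain carbon, it carries 2-(trifluoromethyl)phenyl in place of 4-fluorophenyl (2-(trifluoromethyl)phenyl in place of 4-fluorophenyl on a sulfur). For the measured compounds named here, with no measured step for this change, the data support no direction, and no shift beyond the scatter is expected. The estimated change is a 1.1-fold lower number from compound 2 to compound 3 (0.06 log units; within the scatter) and is expected to stay within the scatter. For compound 3 the expected value is 11000 nM with an estimated range from 4000 nM to 30000 nM for now.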

Compound 3, half-maximal inhibitory concentration: 12300 nM
Beside the measured number, compound 3's estimate is 1.1-fold (0.05 log units) below it; the range from low to high includes it.
By their numbers in this assay, from the lowest: compounds 3, 2 and 1 (each within the scatter of the next).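

On a sulfur whose other neighbours are a saturated chain carbon, 2-(trifluoromethyl)phenyl in place of 4-fluorophenyl gives a 1.0-fold lower number from compound 2 to compound 3 (0.01 log units; within the scatter) in this assay. Among these compounds, this is the first single-change step, so this position now has a measured reading where the earlier compounds offered none: the exchange of 4-fluorophenyl for a group with more heavy atoms leaves the number within the scatter. No measured evidence accounts for this flat step.

Both groups shown on this sulfur are aromatic rings of carbon only bearing fluorine-containing substituents, so a single pair cannot say whether an unsubstituted phenyl, a phenyl carrying an amine or a carboxylic acid, or a saturated chain on the sulfur would also leave the number unchanged. Among the compounds shown here, also open is whether this exchange would read the same when the group on the amide nitrogen is the one carried by compound 1, since no step on that side of the series is available.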